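This account rests on a few compounds, and the source may have more. Where it says the series, first, only, none or still open, it means among the compounds named here.

Working notes on a macrocyclic series tested in an assay on isolated protein for displacement of a labelled ligand from Motilin receptor (Homo sapiens); on this read-out higher numbers stand for weaker inhibition and lower numbers for stronger inhibition. Compound 1, `CCC[C@@H]1NC(=O)[C@@H](C(C)C)NC(=O)[C@@H](Cc2ccc(O)cc2)NCCOc2ccccc2CCCNC1=O`, carries a 4-hydroxyphenyl group on a saturated chain carbon bound to a saturated ring carbon, and in this assay compound 1 gives 55 nM. Compound 2, `CCC[C@@H]1NC(=O)[C@@H](C(C)C)NC(=O)[C@@H](Cc2ccc(O)cc2)NCCOc2ccccc2CCNC1=O`, differs from it only in the length of the saturated chain linking the aromatic ether to the ring amide; in this assay compound 2 gives 982 nM. Going by the values given here, of the two numbers measured so far, compound 1 has the lower one, and its gap to compound 2 lies beyond the usual scatter of repeated measurements.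

Compound 3, `CCC[C@@H]1NC(=O)[C@@H](C(C)C)NC(=O)[C@@H](Cc2cccc3ccccc23)NCCOc2ccccc2CCCNC1=O`, is not yet measured. It differs from compound 1 by the change (naphthalen-1-yl in place of 4-hydroxyphenyl on a saturated chain carbon bound to a saturated ring carbon). Among the compounds with values here, the measured pair offers no guidance on this kind of change, since the only comparison available concerns the chain and not the aromatic group. The step expected in this assay is a 2.7-fold higher number from compound 1 to compound 3 (0.44 log units; beyond the scatter), a modest move toward a higher number, though a result within the scatter cannot be excluded. In this assay compound 3 is estimated at 150 nM, with a range from 40 nM to 600 nM.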

Compound 3, inhibition constant: 8.3 nM
Estimate against measurement, compound 3: 18-fold (1.26 log units) above; measured number below the stated range.
By their numbers in this assay, from the lowest: compound 3; then compound 1; then compound 2.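

In this assay, going by these compounds alone, naphthalen-1-yl in place of 4-hydroxyphenyl on a saturated chain carbon bound to a saturated ring carbon gives a 6.6-fold lower number from compound 1 to compound 3 (0.82 log units; beyond the scatter), the first reading on this place. On the core of compound 1, the hydrogen-bond donor and acceptor counted on 4-hydroxyphenyl are therefore not needed for a low number, and a group with a second six-membered aromatic ring and neither donor nor acceptor is accepted here and reads lower. Nothing on hand bears on the reason for this step.

The change adds a ring and removes the hydroxyl in one move, so the compounds shown do not divide the step between the two; a plain phenyl or a 4-methoxyphenyl at this place would separate them, and naphthalen-2-yl would show whether the point of attachment of the ring system matters. Also open, going by these compounds, is whether naphthalen-1-yl gives a similar step on the shorter chain of compound 2, since the chain and the aromatic group have so far been varied only on separate compounds.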